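From 2-hydroxypropyl to 2-acetoxybutyl on the shared core

The compounds below may be only part of what the source reports. "The series", "measured", "known", "first", "only" and "open" are said of these compounds alone.

In a functional assay on DU-145 cells (Homo sapiens) for cytotoxicity, read by MTT assay (a higher number here means a weaker inhibitor, a lower number a stronger inhibitor), compound 3 `CC(C)=CC[C@@H](OCC(C)O)C1=CC(=O)c2c(O)ccc(O)c2C1=O` gives 16100 nM. Compound 1 `CC(C)=CC[C@@H](OC[C@@H](C)O)C1=CC(=O)c2c(O)ccc(O)c2C1=O` gives 14300 nM and compound 2 `CC[C@](C)(O)CC(=O)O[C@H](CC=C(C)C)C1=CC(=O)c2c(O)ccc(O)c2C1=O` gives 20500 nM. Compound 3 lies within the scatter of both, so the three values form a single group with no rank among them.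

Compound 4 `CCC(CO[C@H](CC=C(C)C)C1=CC(=O)c2c(O)ccc(O)c2C1=O)OC(C)=O` has not yet been measured. It differs from compound 3 as follows: 1-acetoxypropyl in place of 1-hydroxyethyl on a saturated chain carbon bound to an oxygen on a saturated carbon. This is 1-acetoxypropyl in place of 1-hydroxyethyl on a saturated chain carbon bound to an oxygen on a saturated carbon, which turns 2-hydroxypropyl into 2-acetoxybutyl.

The closest measured precedents are the exchanges of 2-hydroxypropyl and (2-hydroxy-2-methylbutyl)carbonyl on an oxygen on a saturated carbon. These gave a 1.4-fold higher number from compound 1 to compound 2 (0.16 log units; within the scatter) and a 1.3-fold lower number from compound 2 to compound 3 (0.10 log units; within the scatter), both small. The remaining step, a 1.1-fold higher number from compound 1 to compound 3 (0.05 log units; within the scatter), reflects only (the fact that one of compounds 1 and 3 is drawn with a defined configuration and the other without, at the place where they differ). Within the data shown here, none of the measured compounds carries a 2-acetoxybutyl chain, so the precedent is indirect and the range is kept wide.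

No change beyond the scatter is therefore expected in this assay. The expected step is a 1.1-fold lower number from compound 3 to compound 4 (0.03 log units; within the scatter). For compound 4 the estimated value is 15000 nM, with an expected range from 6500 nM to 35000 nM.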

Compound 4, half-maximal inhibitory concentration: 25400 nM
The estimate for compound 4 lay 1.7-fold (0.23 log units) below the measured number, within the range that was stated.
By their numbers in this assay, from the lowest: compounds 1, 3, 2 and 4 (each within the scatter of the next).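

Compound 4 shows that this position can take a 2-acetoxybutyl chain, which has 0 hydrogen-bond donors where 2-hydroxypropyl has 1, without a step beyond the scatter in this assay: the exchange gives a 1.6-fold higher number from compound 3 to compound 4 (0.20 log units; within the scatter) and a 1.8-fold higher number from compound 1 to compound 4 (0.25 log units; within the scatter). The earlier compounds had shown this only for the (2-hydroxy-2-methylbutyl)carbonyl group, and the comparison with that group gives a 1.2-fold higher number from compound 2 to compound 4 (0.09 log units; within the scatter), so all four compounds form a single group with no rank among them. The data at hand offer no explanation for these small steps, and since none lies beyond the scatter, they give no sign that this change matters in this assay.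

The compounds shown do not separate the longer chain from the acetoxy group, which 2-hydroxybutyl and 2-acetoxypropyl chains would do. They also leave open whether this position stays as flat with an amine or a carboxylic acid at the end of the chain, since every group shown here carries only carbon and oxygen.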